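This account rests on a few compounds, and the source may have more. Where it says the series, first, only, none or still open, it means among the compounds named here.

Working notes on the series. In an ADME assay on Caco-2 cells (Homo sapiens) for permeability, in the apical to basolateral direction, at pH 7.4 (a higher number here means that the compound crosses the layer faster, a lower number that the compound crosses the layer more slowly), compound 2 (`O=C(N[C@H]1CN(S(=O)(=O)c2ccccc2)C[C@@H]1C(=O)N1C[C@H]2CCNC[C@H]21)c1cc(-c2ccccc2Cl)on1`) gives 0.53 10^-6 cm/s, the highest of the three measured numbers. Compound 1 (`Cc1oc(-c2ccc(C(F)(F)F)cc2)nc1C(=O)N[C@H]1CN(S(=O)(=O)c2ccccc2)C[C@@H]1C(=O)N[C@H]1CCCNC1`) gives 0.1 10^-6 cm/s and compound 3 (`CN(C(=O)c1cc(-c2ccccc2Cl)on1)[C@H]1CN(S(=O)(=O)c2ccccc2)C[C@@H]1C(=O)N[C@H]1CCCNC1`) gives 0.06 10^-6 cm/s, both beyond the scatter from compound 2.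

The next compound to read in this assay is compound 4 (`CC(=O)N1CCC[C@H](NC(=O)[C@H]2CN(S(=O)(=O)c3ccccc3)C[C@@H]2NC(=O)c2cc(-c3ccccc3Cl)on2)C1`). Its structural change from compound 2 is a group of 10 heavy atoms (7 carbon, 2 nitrogen, 1 oxygen; one six-membered non-aromatic ring with 1 hetero atom) in place of a group of 8 heavy atoms (6 carbon, 2 nitrogen; one four-membered non-aromatic ring with 1 hetero atom, one six-membered non-aromatic ring with 1 hetero atom), on a carbonyl carbon. The group that enters sits on the same carbonyl carbon, and the rest of the molecule stays as it is.

Going by the values given here, no two measured compounds differ in one place only, so no measured step anchors this expectation, and it rests on judgement of the structural change alone. Among the compounds with values here, with only three numbers, the uncertainty is wide. A rise modestly beyond the scatter is expected, and the estimated step is a 2.3-fold higher number from compound 2 to compound 4 (0.35 log units; beyond the scatter). The expected value for compound 4 is 1.2 10^-6 cm/s, with an estimated range of 0.25 10^-6 cm/s to 5 10^-6 cm/s.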

Compound 4, apparent permeability in the Caco-2 assay: 0.75 10^-6 cm/s
Estimate against measurement, compound 4: 1.6-fold (0.20 log units) above; low and high end bracket the measured number.
By their numbers in the Caco-2 assay, from the lowest: compounds 3 and 1 (each within the scatter of the next); then compounds 2 and 4 (each within the scatter of the next).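

In the Caco-2 assay compound 2 gives 0.53 10^-6 cm/s and compound 4 gives 0.75 10^-6 cm/s. In the Caco-2 assay the step is a 1.4-fold higher number from compound 2 to compound 4 (0.15 log units; within the scatter), so on this read-out the group of 10 heavy atoms and the group of 8 heavy atoms on the carbonyl carbon do not separate the two compounds. In a physicochemical assay for solubility, at pH 7.4 (on this read-out lower numbers stand for lower solubility and higher numbers for higher solubility), compound 2 gives 265000 nM. From the compounds shown here alone, in the physicochemical assay the same change gives an at least 530-fold lower number from compound 2 to compound 4 (2.72 log units; beyond the scatter), and that step rests on a limit of the assay: the limit of < 500 nM in the physicochemical assay, at which 1 of the 2 values shown sits. In the physicochemical assay compound 4 gives < 500 nM, which is a limit and not a number, so the full size of the step stays unknown.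

The single step changes the whole group at once, so the compounds shown do not tell which part of it goes with the difference in the physicochemical assay. Going by these compounds, how a carboxylic acid or a primary amine on the same carbonyl carbon would read on either read-out stays open.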